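Iodine Removal on Two Fused Five-Membered Cores

This account rests on a few compounds, and the source may have more. Where it says the series, first, only, none or still open, it means among the compounds named here.

The account concerns three measured compounds and one that awaits measurement in a functional assay on NCI-H522 cells (Homo sapiens) for cytotoxicity, with a stated time of 3 days; a lower number here means a stronger inhibitor, a higher number a weaker inhibitor. Compound 1, `Cn1c(I)nc2ccccc21`, gives 1020 nM in this assay. Compound 2, `Cn1cnc2ccccc21`, differs from compound 1 by hydrogen in place of iodo on an aromatic carbon. In this assay compound 2 gives > 40000 nM, which is a limit of the assay and not a number. The measured step is an at least 39-fold higher number from compound 1 to compound 2 (1.59 log units; beyond the scatter). Its size is set by the limit of > 40000 nM in this assay, at which 2 of the 3 values shown sit.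

Compound 3, `Ic1nc2ccccc2[se]1`, is built on a different core; the difference between the two cores is not broken down here. In this assay compound 3 gives > 40000 nM, again a limit of the assay rather than a number.

Compound 4, `c1ccc2[se]cnc2c1`, has not yet been measured. It differs from compound 3 by hydrogen in place of iodo on an aromatic carbon. Among the compounds with values here, this is the same kind of change as the one from compound 1 to compound 2, but not the same: in compound 1 the carbon lies between two ring nitrogen atoms and next to the ring atom that bears a methyl group, whereas in compound 3 it lies next to the ring nitrogen and next to the ring selenium.

Within the data shown here, the expected step is a step that the limit leaves unreadable from compound 3 to compound 4, resting on the single measured instance, an at least 39-fold higher number from compound 1 to compound 2 (1.59 log units; beyond the scatter). Compound 4 is expected to give 80000 nM, most likely reported only as a limit, with an estimated range from 40000 nM to 200000 nM.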

Compound 4, half-maximal inhibitory concentration: > 40000 nM
Compound 4 ended at the assay's limit (the forecaster's own chance of this, stated with the estimate: 95%); the middle value lies beyond the limit too.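

In this assay no step can be read from compound 3 to compound 4, because both compounds end at a limit of the assay and not at a number: the limit of > 40000 nM in this assay, at which 3 of the 4 values shown sit. Against an at least 39-fold higher number from compound 1 to compound 2 (1.59 log units; beyond the scatter) on the core of compound 1, the compounds shown leave open what hydrogen in place of iodo on an aromatic carbon does on the core of compound 3.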